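The source may hold more compounds than are shown below. What is called first, only, known or untested is meant among the compounds shown, and "the series" means these compounds.

Compound 2 `COc1ccc(C(=O)/C=C/c2cc(-c3cc(OC)c(OC)c(OC)c3)n[nH]2)cc1OC` and compound 1 `COc1cc(-c2cc(/C=C/C(=O)c3ccc(N)cc3)[nH]n2)cc(OC)c1OC` share one core and differ only in the aryl group attached to the carbonyl carbon. In a functional assay on SK-MEL-5 cells (Homo sapiens) for cytotoxicity, read by sulforhodamine B assay, with a stated time of 48 h, tested at 0.1 uM (a higher number here means a weaker effect of the compound at the concentration tested, a lower number a stronger effect), compound 2 gives 96%, and in the same test compound 1 gives 95%; the two numbers sit within the usual scatter of each other, so neither compound can be placed above the other, and both show only a weak effect at this concentration.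

Compound 3 `COc1ccc(C(=O)/C=C/c2cc(-c3cc(OC)c(OC)c(OC)c3)n[nH]2)cc1` is the next member. It differs from compound 2 in one place: hydrogen in place of methoxy on an aromatic carbon.

Within the data shown here, only one measured step speaks to this position. Exchanging the whole aryl group on the carbonyl carbon moved the read-out by a number 1 percentage points higher from compound 1 to compound 2 (within the scatter), a step within the scatter. Removing one methoxy from that same aryl is a smaller change than that exchange, so no step beyond the scatter is expected here either; the expected step is no change at the digits printed from compound 2 to compound 3 (within the scatter).

For compound 3 the estimated value in this assay is 96%, with an expected range from 87% to 104%.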

Compound 3, a percentage reported as activity, at one concentration (the size of the read-out at that concentration, not a potency): 99%
Beside the measured number, compound 3's estimate is 3 percentage points below it, and the stated range covers the measured number.
By their numbers in this assay, from the lowest: compounds 1, 2 and 3 (each within the scatter of the next).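

In this assay the swap to hydrogen, on an aromatic carbon ortho to a methoxy group, gives a number 3 percentage points higher from compound 2 to compound 3 (within the scatter) and so cannot be told apart from no effect: at this concentration, the read-out does not depend on this methoxy. The earlier step exchanged a whole aryl group, whereas methoxy in place of amino on an aromatic carbon is a single-place change, and it gives a number 4 percentage points higher from compound 1 to compound 3 (within the scatter) with no readable difference either, so 4-aminophenyl, 3,4-dimethoxyphenyl and 4-methoxyphenyl on the carbonyl carbon cannot be ranked in this test. No measured evidence is available to explain this outcome.

On these data alone, all three compounds show only a weak effect at this one concentration, so it stays open whether these aryl groups would separate at a higher concentration, where a stronger effect could reveal differences. The compounds shown also leave open what a hydroxy group, a chlorine atom or a carboxylic acid would do on this aryl ring, and whether a longer chain such as ethoxy in place of methoxy would move the read-out beyond the scatter.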